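Swapping the ring-nitrogen substituent of a rhodanine-type core

The source may hold more compounds than are shown below. What is called first, only, known or untested is meant among the compounds shown, and "the series" means these compounds.

Compound 1 `CN1C(=O)/C(=C/N2N=C(c3ccccc3)CC2c2ccccc2O)SC1=S` carries a methyl group on the amide-type nitrogen of its five-membered ring. In a functional assay on HL-60 cells (Homo sapiens) for antiproliferative activity, read by MTT assay, with a stated time of 72 h (on this read-out higher numbers stand for weaker inhibition and lower numbers for stronger inhibition), compound 1 gives 2880 nM. Compound 2 `O=C1/C(=C/N2N=C(c3ccccc3)CC2c2ccccc2O)SC(=S)N1c1cccc(C(F)(F)F)c1` carries a 3-(trifluoromethyl)phenyl group in that position instead. In this assay compound 2 reaches only > 10000 nM, which is a limit of the assay rather than a number, as described by the limit of > 10000 nM in this assay, at which 1 of the 2 values shown sits. For the measured compounds named here, the single measured step, an at least 3.4-fold higher number from compound 1 to compound 2 (0.54 log units; beyond the scatter), shows that the aromatic group weakens inhibition compared with the small methyl group.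

Compound 3 `CCOC(=O)CCN1C(=O)/C(=C/N2N=C(c3ccccc3)CC2c2ccccc2O)SC1=S` is not yet measured. It differs from compound 2 in one place: 2-(ethoxycarbonyl)ethyl in place of 3-(trifluoromethyl)phenyl on an amide-type nitrogen in a ring. The step from compound 1 to compound 2 is the only one that bears on this change, and it runs in the opposite direction, since compound 3 returns to a substituent without a ring. A move back toward the number of compound 1 is therefore expected, with compound 3 estimated at 4500 nM (range 1500 nM to 13000 nM), meaning an expected step of an at least 2.2-fold lower number from compound 2 to compound 3 (0.34 log units; beyond the scatter).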

Compound 3, half-maximal inhibitory concentration: > 10000 nM
Compound 3 ended at the assay's limit; the forecaster's own chance of this, stated with the estimate: 30%; at least 2.2-fold (0.34 log units) between middle value and limit.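

The aromatic ring is not needed for this drop in inhibition: in this assay, putting the ringless 2-(ethoxycarbonyl)ethyl group in place of methyl gives an at least 3.4-fold higher number from compound 1 to compound 3 (0.54 log units; beyond the scatter). Among the three compounds shown, the methyl group of compound 1 is therefore the only substituent on this nitrogen that gives a readable number, whether the replacement has an aromatic ring, as in compound 2, or an ester chain with two hydrogen-bond acceptors, as in compound 3. Compound 3 sits at a limit of the assay rather than at a number, as does compound 2, so the step between them cannot be read and neither group can be ranked against the other: the limit of > 10000 nM in this assay, at which 2 of the 3 values shown sit.

From the compounds shown here alone, it remains open whether the weaker inhibition follows from the length of the chain or from the ester itself, and how far compound 2 and compound 3 lie beyond the limit. A plain ethyl group on this nitrogen, or a free carboxylic acid in place of the ethyl ester, would help separate these two possibilities.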